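The compounds below may be only part of what the source reports. "The series", "measured", "known", "first", "only" and "open" are said of these compounds alone.

Measured so far in a functional assay on HCT-116 cells (Homo sapiens) for inhibition, read by MTT assay, with a stated time of 48 h; a lower number here means a stronger inhibitor, a higher number a weaker inhibitor:
compound 1 `COc1ccc(CN(C(=O)CCl)c2cc(OC)c(OC)c(OC)c2)cc1O` gives 250 nM;
compound 2 `C/C=C/C(=O)N(Cc1cc(OC)c(OC)c(OC)c1)c1ccc(OC)c(O)c1` gives 8450 nM;
compound 3 `COC(=O)c1cc(CNc2cc(OC)c(OC)c(OC)c2)ccc1OC` gives 38100 nM.

Of these three numbers, compound 3 has the highest, and its distance from compound 2 as well as from compound 1 lies beyond the scatter, so it is the weakest inhibitor of the three. Compound 4 `COc1ccc(CNc2cc(OC)c(OC)c(OC)c2)cc1F` differs from compound 3 in one place: fluoro in place of methoxycarbonyl on an aromatic carbon. Among the compounds with values here, no pair of measured compounds differs in a single place, so nothing in the data shows how large such a step tends to be. Compound 4 is expected to land near compound 3, estimated at 20000 nM with a range from 5000 nM to 80000 nM. The estimated step of a 1.9-fold lower number from compound 3 to compound 4 (0.28 log units; within the scatter) is expected to be modest, toward a lower number, and close to the scatter.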

Compound 4, half-maximal inhibitory concentration: 32200 nM
For compound 4 the middle estimate is 1.6-fold (0.21 log units) below the measured one; the measured number falls inside the stated range.
By their numbers in this assay, from the lowest: compound 1; then compound 2; then compounds 4 and 3 (each within the scatter of the next).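

In this assay, within the data shown here, fluoro in place of methoxycarbonyl on this aromatic carbon, ortho to a methoxy group, gives a 1.2-fold lower number from compound 3 to compound 4 (0.07 log units; within the scatter) and is the first single-place step available in this set. It shows that the carbonyl and both oxygens of methoxycarbonyl can leave this position without a reading beyond the scatter. No measurement shown bears on why the two compounds read alike. The compounds shown leave open whether an amine, a carboxylic acid or a longer chain on this carbon would stay within the scatter of compound 3.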